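Swapping phenyl for pyridin-2-yl on the piperazine of compound 2

The source may hold more compounds than are shown below. What is called first, only, known or untested is meant among the compounds shown, and "the series" means these compounds.

Measured compounds:
compound 1, `c1ccc2c(c1)ccn2-c1nc(N2CCNCC2)nc2ccccc12`, 8.2 ug/mL
compound 2, `c1ccc(N2CCN(c3nc(-n4ccc5ccccc54)c4ccccc4n3)CC2)cc1`, 50 ug/mL
compound 3, `COc1cc(OC)c(-c2nc(N3CCN(C)CC3)nc3ccccc23)c(OC)c1`, 50 ug/mL

In a functional assay on C-33-A cells (Homo sapiens) for antiproliferative activity, read by MTT assay (a higher number here means a weaker inhibitor, a lower number a stronger inhibitor), compound 2 stands level with compound 3 at the digits shown, and together these two carry the highest numbers of the three; compound 1 sits furthest away, the step of a 6.1-fold higher number from compound 1 to compound 2 (0.79 log units; beyond the scatter) being the only one-point change available. That step added a phenyl where compound 1 carried a hydrogen on the amine nitrogen in the ring. Compound 4, `c1ccc(N2CCN(c3nc(-n4ccc5ccccc54)c4ccccc4n3)CC2)nc1`, differs from compound 2 by pyridin-2-yl in place of phenyl on an amine nitrogen in a ring. Among the compounds with values here, no measured pair bears directly on an exchange of phenyl for pyridin-2-yl at this position, so the only guidance is that the arene at this nitrogen is already present in compound 2 and that compound 3, with a quite different substituent there, shows the same number. The step of a 1.3-fold lower number from compound 2 to compound 4 (0.10 log units; within the scatter) is therefore expected to stay within the scatter, with no direction favoured. Compound 4 is estimated to give 40 ug/mL, within a range of 15 ug/mL to 100 ug/mL.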

Compound 4, half-maximal inhibitory concentration: 50 ug/mL
Compound 4: the middle estimate sits 1.3-fold (0.10 log units) below what was measured, within the range that was stated.
By their numbers in this assay, from the lowest: compound 1; then compounds 2, 3 and 4 (each within the scatter of the next).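

In this assay, pyridin-2-yl in place of phenyl on the amine nitrogen in a ring gives no change at the digits printed from compound 2 to compound 4 (within the scatter), so at this position the hydrogen-bond acceptor counted for the entering ring leaves the two compounds indistinguishable. Set against the free amine, pyridin-2-yl gives a 6.1-fold higher number from compound 1 to compound 4 (0.79 log units; beyond the scatter), a step that matches a 6.1-fold higher number from compound 1 to compound 2 (0.79 log units; beyond the scatter), so for these two aromatic rings the gap from compound 1 does not depend on which ring is attached. Nothing measured here accounts for this.

As far as these compounds go, whether any group on this nitrogen would open the same gap, or only an aromatic ring, remains open. A benzyl or an acetyl group there, or an amine or a carboxylic acid on the pyridine ring, could help to settle that.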